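Shrinking the amide substituent of the weakest compound

This account rests on a few compounds, and the source may have more. Where it says the series, first, only, none or still open, it means among the compounds named here.

So far, three compounds sharing one core have been measured in a functional assay on BXPC-3 cells (Homo sapiens) for inhibition, read by MTT assay, with a stated time of 7 days; a lower number here means a stronger inhibitor, a higher number a weaker inhibitor. Compound 1 `CCN(CC)S(=O)(=O)c1ccc(S(=O)(=O)N2CCC[C@@H](C(=O)N3CCOCC3)C2)cc1` gives 790 nM. Compound 2 `CCN(CC)S(=O)(=O)c1ccc(S(=O)(=O)N2CCC[C@@H](C(=O)N3CCC(C(F)(F)F)CC3)C2)cc1` gives 370 nM, which is a 2.1-fold lower number from compound 1 to compound 2 (0.33 log units; beyond the scatter). Compound 3 `CCN(CC)S(=O)(=O)c1ccc(S(=O)(=O)N2CCC[C@@H](C(=O)N[C@H]3CC[C@@H](OC)CC3)C2)cc1` gives 2150 nM and so stands highest of the three, that is, as the weakest inhibitor: the move was a 2.7-fold higher number from compound 1 to compound 3 (0.43 log units; beyond the scatter) and a 5.8-fold higher number from compound 2 to compound 3 (0.76 log units; beyond the scatter).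

Compound 4 `CCN(CC)S(=O)(=O)c1ccc(S(=O)(=O)N2CCC[C@@H](C(=O)N[C@@H]3CCOC3)C2)cc1` has not yet been measured. It differs from compound 3 in one place: oxolan-3-yl in place of 4-methoxycyclohexyl on an amide-type nitrogen. Both keep the amide hydrogen, which compound 1 and compound 2 lack. Going by the values given here, no measured step changes the ring on this amide nitrogen while keeping that hydrogen, so the two steps that end at compound 3 only set the neighbourhood; neither speaks directly to the exchange.

Given that, compound 4 is expected to land near compound 3, with a 1.2-fold higher number from compound 3 to compound 4 (0.07 log units; within the scatter) as the estimated step. The estimate for compound 4 in this assay is 2500 nM, within a range from 800 nM to 8000 nM.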

Compound 4, half-maximal inhibitory concentration: 2270 nM
Estimate against measurement, compound 4: 1.1-fold (0.04 log units) above, and the stated range covers the measured number.
By their numbers in this assay, from the lowest: compound 2; then compound 1; then compounds 3 and 4 (each within the scatter of the next).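

In this assay, going by these compounds alone, the first exchange of the ring on the amide nitrogen with the amide hydrogen kept, from 4-methoxycyclohexyl to the smaller oxolan-3-yl, gives a 1.1-fold higher number from compound 3 to compound 4 (0.02 log units; within the scatter), so this change of ring size and shape does not separate the two compounds in this cell read-out. Compound 4 also stays clearly apart from the compounds that lack the amide hydrogen, with a 2.9-fold higher number from compound 1 to compound 4 (0.46 log units; beyond the scatter) and a 6.1-fold higher number from compound 2 to compound 4 (0.79 log units; beyond the scatter), just as compound 3 does. Nothing available here explains why the two rings read alike.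

Whether the amide hydrogen itself accounts for those gaps stays open: every step that removes it also changes the ring. Also open, on these data alone, is how an ethyl chain or a carboxylic acid on this amide nitrogen would read.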